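The compounds below may be only part of what the source reports. "The series", "measured", "known", "first", "only" and "open" are said of these compounds alone.

Compound 3, `OC1C=C[C@]2(O)CCO[C@@H]2C1`, carries two free hydroxyl groups on the shared core and no ketone. In a functional assay on HeLa S3 cells (Homo sapiens) for cytotoxicity (on this read-out higher numbers stand for weaker inhibition and lower numbers for stronger inhibition), compound 3 gives > 100 ug/mL, which is a limit of the assay and not a number, so compound 3 sits at the limit of > 100 ug/mL in this assay, at which 1 of the 3 values shown sits. Compound 4, `CCCC(=O)O[C@]12C=CC(O)C[C@H]1OCC2`, differs from it by propylcarbonyl in place of hydrogen on an oxygen on a saturated carbon. The ester analogues compound 1, `CC(=O)O[C@]12C=CC(=O)C[C@H]1OCC2`, and compound 2, `CCCCCC(=O)O[C@]12C=CC(=O)C[C@H]1OCC2`, both keep the enone that compound 4 lacks; compound 1 gives 4.1 ug/mL and compound 2 gives 1.8 ug/mL, with a 2.3-fold lower number from compound 1 to compound 2 (0.36 log units; beyond the scatter). Within the data shown here, no measured step covers hydrogen giving way to an acyl group on this oxygen. Compound 4 is therefore expected to show an at least 2.0-fold lower number from compound 3 to compound 4 (0.30 log units; that floor lies within the scatter), with an estimate of 50 ug/mL spanning 12 ug/mL to 150 ug/mL.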

Compound 4, half-maximal inhibitory concentration: 8.8 ug/mL
The estimate for compound 4 lay 5.7-fold (0.75 log units) above the measured number; the whole stated range lies above it.
By their numbers in this assay, from the lowest: compound 2; then compound 1; then compound 4. At a limit, above all of these: compound 3.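

In this assay, propylcarbonyl in place of hydrogen on an oxygen on a saturated carbon gives an at least 11-fold lower number from compound 3 to compound 4 (1.05 log units; beyond the scatter), and neither compound carries the ketone. The earlier step only lengthened a chain on an ester already present, whereas this one shows that the acyl group itself, set on a free hydroxyl, moves the read-out. The value of compound 3 is a limit of the assay, so the step has a floor and no measured size: the limit of > 100 ug/mL in this assay, at which 1 of the 4 values shown sits.

The compounds shown leave open how a longer chain on this oxygen, or an amine in the same place, would read. They also leave open what the ketone contributes with the propylcarbonyl group in place.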